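The source may hold more compounds than are shown below. What is called first, only, known or untested is meant among the compounds shown, and "the series" means these compounds.

Three compounds have been measured in a functional assay on the whole organism (Tail, strain ICR) with Mus musculus as the target, in the tail flick test, with a stated time of 150 min, at a dose of 25 umol/kg by the oral route; on this read-out lower numbers stand for a weaker effect and higher numbers for a stronger effect at the one dose given:

Compound 1, `C[C@@H](O)[C@H](NC(=O)CN(c1nc(Cl)nc2[nH]cnc12)C1CC1)C(=O)O`, gives 24%.
Compound 2, `C[C@H](NC(=O)CN(c1nc(Cl)nc2[nH]cnc12)C1CC1)C(=O)O`, gives 14.7%.
Compound 3, `O=C(O)C[C@H](NC(=O)CN(c1nc(Cl)nc2[nH]cnc12)C1CC1)C(=O)O`, gives 11.6%.

Compound 3 stands at the low end of these three numbers. Its gap to compound 2 is small, a number 3.1 percentage points lower from compound 2 to compound 3 (within the scatter), whereas the gap to compound 1 is larger, a number 12.4 percentage points lower from compound 1 to compound 3 (beyond the scatter). Compound 4, `NC(=O)CC[C@H](NC(=O)CN(c1nc(Cl)nc2[nH]cnc12)C1CC1)C(=O)O`, differs from compound 3 by carbamoylmethyl in place of carboxy on a saturated chain carbon, two bonds along the chain from an amide-type nitrogen and a carbonyl carbon. Among the compounds with values here, the only measured step at that same place is a number 3.1 percentage points lower from compound 2 to compound 3 (within the scatter), and the full spread across all three measured compounds is narrow. Compound 4 is therefore expected to show a number 2.4 percentage points higher from compound 3 to compound 4 (within the scatter), no shift beyond the scatter in this assay. The estimate for compound 4 is 14%, within a range from 5% to 25%.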

Compound 4, a percentage reported as activity, at one dose (the size of the read-out at that dose, not a potency): 11.4%
Compound 4: middle estimate off by 2.6 percentage points, on the high side; measured number inside the range.
By their numbers in this assay, from the lowest: compounds 4, 3, 2 and 1 (each within the scatter of the next, the first and the last beyond it).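

Placing carbamoylmethyl instead of carboxy on this saturated chain carbon gives no difference that can be separated in this assay (a number 0.2 percentage points lower from compound 3 to compound 4 (within the scatter)), and carbamoylmethyl in place of hydrogen gives none either (a number 3.3 percentage points lower from compound 2 to compound 4 (within the scatter)). The 2-carbamoylethyl side chain stands clearly apart only from 1-hydroxyethyl (a number 12.6 percentage points lower from compound 1 to compound 4 (beyond the scatter)), although methyl does not (a number 9.3 percentage points lower from compound 1 to compound 2 (within the scatter)). Nothing available explains these results. The compounds shown leave open whether an amine at the end of a longer chain, or a benzyl group, on this carbon would give a number clearly above that of compound 1.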